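From Ethoxycarbonyl to Benzyl on a Shared Core

A few compounds are considered here, and "the series" means these few. Any claim that something is new, unique, unknown or untested is made for them only; others in the source may bear on it.

For the measured compounds named here, in a functional assay on A549 cells (Homo sapiens) for antiproliferative activity, read by luminescence, with a stated time of 72 h (a lower number here means a stronger inhibitor, a higher number a weaker inhibitor), compound 1 (`CC(=O)N1CC2(CC(=O)c3cc(/C=C/C(=O)NO)ccc3O2)C1`) gives 47700 nM and compound 2 (`CCOC(=O)N1CC2(CC(=O)c3cc(/C=C/C(=O)NO)ccc3O2)C1`) gives 4870 nM as the lower of the two numbers measured so far. Compound 3 (`O=C(/C=C/c1ccc2c(c1)C(=O)CC1(CN(Cc3ccccc3)C1)O2)NO`) has not yet been measured. It carries benzyl in place of ethoxycarbonyl on an amine nitrogen in a ring on the shared core.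

Going by the values given here, only one measured step bears on this change. That is a 9.8-fold lower number from compound 1 to compound 2 (0.99 log units; beyond the scatter) for ethoxy in place of methyl on a carbonyl carbon, a modest step beyond the scatter. It alters the group on the same amine nitrogen but keeps the carbonyl, which is lost in compound 3, so it is only a loose guide. A smaller step than that one is expected, toward a lower number, and the direction rests on this single pair. The estimated change is a 2.2-fold lower number from compound 2 to compound 3 (0.35 log units; beyond the scatter) in this assay and may still fall within the scatter. For compound 3 the expected value is 2200 nM with an estimated range of 450 nM to 10000 nM in this assay.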

Compound 3, half-maximal inhibitory concentration: 245 nM
The estimate for compound 3 lay 9.0-fold (0.95 log units) above the measured number, and the stated range ends above it.
By their numbers in this assay, from the lowest: compound 3; then compound 2; then compound 1.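

In this assay, the earlier pair showed only a change within the carbonyl-bearing groups on this nitrogen, a 9.8-fold lower number from compound 1 to compound 2 (0.99 log units; beyond the scatter), a step of modest size. Compound 3 shows that this amine nitrogen in the four-membered ring also tolerates a group with no carbonyl at all, and that benzyl in place of ethoxycarbonyl gives a 20-fold lower number from compound 2 to compound 3 (1.30 log units; beyond the scatter), while benzyl in place of acetyl gives a 190-fold lower number from compound 1 to compound 3 (2.29 log units; beyond the scatter), so that compound 3 has the lowest number of the three, with both steps large and beyond the scatter. Nothing at hand speaks to the reason for these steps.

The swap removes the carbonyl and brings in a six-membered aromatic ring of carbon only in a single change, so the three compounds leave open which of the two carries the step. A benzoyl group, which holds both the carbonyl and the aromatic ring, and a plain ethyl group, which holds neither, would tell them apart on the shared core.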